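A few compounds are considered here, and "the series" means these few. Any claim that something is new, unique, unknown or untested is made for them only; others in the source may bear on it.

Compound 1 `O=C(O)[C@H](CO)NC(=O)N1CCCC1`: "not determined" (no result reported)
Compound 2 `O=C(CCO)N[C@@H](CO)C(=O)O`: 96%
Compound 3 `CC(C)C(=O)N[C@@H](CO)C(=O)O`: 84%

In an ADME assay on microsomes from liver (Homo sapiens) for metabolic stability, with a stated time of 30 min (a higher number here means that more of the compound is left, a lower number that less of the compound is left), compound 3 gives 84%, the lower of the two numbers available. Going by the values given here, the only other number belongs to compound 2, at 96%, while compound 1 has no reported result. The next compound, compound 4 `C=C(C)C(=O)N[C@@H](CO)C(=O)O`, remains to be tested. It differs from compound 3 by one structural change: 1-methylethenyl in place of isopropyl on a carbonyl carbon. Among the compounds with values here, the double bond in the 1-methylethenyl group is the new feature, and no tested compound here carries that group.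

Within the data shown here, only one measured step bears on this change: a number 12 percentage points lower from compound 2 to compound 3 (beyond the scatter). That step is modest but beyond the scatter. It also occurred on a carbonyl carbon, yet it replaced 2-hydroxyethyl with isopropyl, so it offers only a rough guide to size and none to direction. With so little evidence, the starting point is compound 3 at 84%, and no change beyond the scatter is expected. The estimated step is a number 1 percentage points higher from compound 3 to compound 4 (within the scatter). Compound 4 is expected to give 85%, within an estimated range of 71% to 97%.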

Compound 4, percent of the compound remaining: 82%
Compound 4: middle estimate off by 3 percentage points, on the high side, within the range that was stated.
By their numbers in this assay, from the lowest: compounds 4 and 3 (each within the scatter of the next); then compound 2.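

In this assay, 1-methylethenyl in place of isopropyl on a carbonyl carbon gives a number 2 percentage points lower from compound 3 to compound 4 (within the scatter) and stays within the scatter, so adding a double bond outside aromatic rings while keeping the same number of heavy atoms leaves no measurable mark here. The change from 2-hydroxyethyl to 1-methylethenyl gives a number 14 percentage points lower from compound 2 to compound 4 (beyond the scatter) and lies beyond the scatter, as does the change to isopropyl, so among these three groups only 2-hydroxyethyl stands apart, with the highest number. No measurement shown here explains this pattern.

On these data alone, it remains open whether the hydroxyl of 2-hydroxyethyl accounts for that higher number or whether its chain matters as well. An amine or a longer unbranched carbon chain on the same carbonyl carbon could help separate these possibilities.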